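This account rests on a few compounds, and the source may have more. Where it says the series, first, only, none or still open, it means among the compounds named here.

Compound 2, `Cc1ncccc1-c1cnc(NCc2c(F)ccc3c2CCO3)c2n[nH]c(=O)n12`, is one of three measured compounds in this series. In an ADME assay on microsomes from liver (Homo sapiens) for metabolic stability, read by LC-MS, using NADPH, with stated times of 5 min and 30 min, tested at 1 uM (a lower number here means slower removal, a higher number faster removal of the compound), compound 2 gives 8 mL.min-1.g-1. Compound 1, `O=C(Nc1cnc(NCc2c(F)ccc3c2CCO3)n2cnnc12)c1ccccc1`, gives in this assay a number of 10 mL.min-1.g-1, which lies within the scatter of compound 2, so no order between the two can be read. Compound 3, `CNC(=O)c1ncc(-c2cnc(NCc3c(F)ccc4c3CCO4)c3cn[nH]c(=O)c23)n1C`, gives in this assay a value of 24 mL.min-1.g-1, higher than compound 2 by a margin beyond the scatter; among the three, only compound 3 is clearly separated from compound 2.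

Compound 4, `Cc1ncccc1-c1cnc(NCc2c(F)ccc3c2CCO3)c2nn(CC#N)c(=O)n12`, differs from compound 2 in one place: cyanomethyl in place of hydrogen on an aromatic nitrogen. Within the data shown here, no step between two measured compounds carries this change, so its effect is unknown from the data. In this assay the step for compound 4 is expected to be a 1.5-fold higher number from compound 2 to compound 4 (0.18 log units; within the scatter). Compound 4 is therefore estimated at 12 mL.min-1.g-1, with a range from 6 mL.min-1.g-1 to 30 mL.min-1.g-1.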

Compound 4, intrinsic clearance in microsomes in the Homo sapiens assay: 151 mL.min-1.g-1
Compound 4: middle estimate off by 13-fold (1.10 log units), on the low side; measured number above the stated range.
By their numbers in the Homo sapiens assay, from the lowest: compounds 2 and 1 (each within the scatter of the next); then compound 3; then compound 4.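

Among these compounds, in the Homo sapiens assay, cyanomethyl in place of hydrogen on this aromatic nitrogen brings a 19-fold higher number from compound 2 to compound 4 (1.28 log units; beyond the scatter), showing for the first time that this position is far from silent in this assay, since no step among the first three compounds touched it. In a physicochemical assay for solubility, read by LC-MS, in phosphate buffer, with a stated time of 24 h, at pH 7.4 (a lower number here means a less soluble compound, a higher number a more soluble compound), compound 2 gives < 2000 nM, which is a limit of the assay and not a number. In the physicochemical assay compound 4 gives 4000 nM, which leaves an at least 2.0-fold higher number from compound 2 to compound 4 (0.30 log units; that floor lies within the scatter) as all that can be read of this change.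

On these data alone, the true gap in the physicochemical assay stays open because compound 2 stands at a limit: the limit of < 2000 nM in the physicochemical assay, at which 1 of the 2 values shown sits. Also open is whether the step in the Homo sapiens assay belongs to the nitrile or to any group on this nitrogen, which a methyl or a longer chain without a nitrile would separate.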